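From a Pyrrolidine to a Triazole

The source may hold more compounds than are shown below. What is called first, only, known or untested is meant among the compounds shown, and "the series" means these compounds.

In a functional assay on MCF7 cells (Homo sapiens) for antiproliferative activity, read by MTT assay, with a stated time of 48 h (a lower number here means a stronger inhibitor, a higher number a weaker inhibitor), compound 1 (`CC(=O)OC/C1=C/C[C@](C)(CCC=C(C)C)/C=C/[C@@H](OC(=O)C=C(C)C)[C@](C)(O)/C=C/C1=O`) gives 4510 nM and compound 2 (`CC(C)=CCC[C@]1(C)/C=C/[C@@H](OC(=O)C=C(C)C)[C@](C)(O)/C=C/C(=O)/C(C=O)=C\C1`) gives 12600 nM, while compound 3 (`CC(C)=CCC[C@]1(C)/C=C/[C@@H](OC(=O)C=C(C)C)[C@](C)(O)/C=C/C(=O)/C(CN2CCCC2)=C\C1`) gives 220 nM as the lowest number of the three. Compound 4 (`CC(C)=CCC[C@]1(C)/C=C/[C@@H](OC(=O)C=C(C)C)[C@](C)(O)/C=C/C(=O)/C(Cn2cc(CO)nn2)=C\C1`) keeps the core of compound 3 and differs on a saturated chain carbon bound to a double-bonded ring carbon: 4-(hydroxymethyl)-1H-1,2,3-triazol-1-yl in place of pyrrolidin-1-yl on a saturated chain carbon bound to a double-bonded ring carbon in all. Two large steps bear on this change, since each brings in the departing pyrrolidin-1-yl: a 21-fold lower number from compound 1 to compound 3 (1.31 log units; beyond the scatter) and a 57-fold lower number from compound 2 to compound 3 (1.76 log units; beyond the scatter) in turn. The step without it, a 2.8-fold higher number from compound 1 to compound 2 (0.45 log units; beyond the scatter) here, is modest. No triazole has been tested, so a higher number is expected in this assay with part of those gains lost. The expected step is a 9.1-fold higher number from compound 3 to compound 4 (0.96 log units; beyond the scatter) overall. Compound 4 is estimated at 2000 nM within a range from 500 nM to 8000 nM here.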

Compound 4, half-maximal inhibitory concentration: 2930 nM
For compound 4 the middle estimate is 1.5-fold (0.17 log units) below the measured one, and the stated range covers the measured number.
By their numbers in this assay, from the lowest: compound 3; then compounds 4 and 1 (each within the scatter of the next); then compound 2.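

In this assay the large gain at this place does not survive every five-membered ring, since 4-(hydroxymethyl)-1H-1,2,3-triazol-1-yl in place of pyrrolidin-1-yl gives a 13-fold higher number from compound 3 to compound 4 (1.12 log units; beyond the scatter) overall. The triazole still keeps part of the gain over the formyl group, with a 4.3-fold lower number from compound 2 to compound 4 (0.63 log units; beyond the scatter) here, while against the acetoxy group it shows a 1.5-fold lower number from compound 1 to compound 4 (0.19 log units; within the scatter) and so no real difference. No evidence at hand explains the gap between the two rings. Open questions remain for other amines on this carbon, such as piperidine, morpholine or dimethylamine, and for the triazole without its hydroxymethyl.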